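The compounds below may be only part of what the source reports. "The series", "measured", "known", "first", "only" and "open" are said of these compounds alone.

Compound 3 `COc1ccc(S(=O)(=O)c2cnc3cc(F)ccc3c2-c2ccc(F)cc2)cc1` was tested in an ADME assay on microsomes from liver (Homo sapiens) for metabolic stability, tested at 2.5 uM (on this read-out lower numbers stand for slow clearance and higher numbers for fast clearance), where compound 3 gives 1.71 mL/min. Among the three compounds measured so far this is the highest number, but the gap to the nearest one, compound 2 `COc1ccc(-c2c(S(=O)(=O)c3ccc(OC)cc3)cnc3cc(F)ccc23)cc1`, which gives 1.18 mL/min, is within the scatter, so the two cannot be told apart. The furthest is compound 1 `O=S(=O)(c1ccc(F)c(Cl)c1)c1cnc2cc(F)ccc2c1-c1ccc(Cl)cc1`, which gives 0.39 mL/min, a gap that is beyond the scatter. Among the compounds with values here, the only single change measured, a 1.4-fold higher number from compound 2 to compound 3 (0.16 log units; within the scatter), stays within the scatter.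

Compound 4 `COc1ccc(S(=O)(=O)c2cnc3cc(F)ccc3c2-c2ccc(Cl)cc2)cc1` differs from compound 3 by chloro in place of fluoro on an aromatic carbon. Within the data shown here, no measured pair shows this change on its own. Compound 1 carries chloro at that place and gives a lower number than compound 3, but compound 1 also differs elsewhere, so its value cannot be assigned to this change. Among the measured compounds shown here, the one measured step, with its small size, concerns a different group. With nothing pointing to a clear shift, compound 4 is expected to sit close to compound 3, with a step of a 1.1-fold lower number from compound 3 to compound 4 (0.06 log units; within the scatter) that stays within the scatter. The estimate for compound 4 is therefore 1.5 mL/min, with a range from 0.7 mL/min to 3.2 mL/min.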

Compound 4, intrinsic clearance in a liver preparation (reported as CLH), per the amount of preparation that the assay uses: 1.28 mL/min
For compound 4 the middle estimate is 1.2-fold (0.07 log units) above the measured one; measured number inside the range.
By their numbers in this assay, from the lowest: compound 1; then compounds 2, 4 and 3 (each within the scatter of the next).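

In this assay the change from 4-fluorophenyl to 4-chlorophenyl now has a measured pair of its own, and that pair gives a 1.3-fold lower number from compound 3 to compound 4 (0.13 log units; within the scatter) so chloro and fluoro cannot be told apart at this place. Chloro and methoxy cannot be told apart here either, with a 1.1-fold higher number from compound 2 to compound 4 (0.04 log units; within the scatter) so all three groups tested on this aromatic carbon give numbers within the scatter of one another. The step beyond the scatter comes from the other side of the molecule, where 4-methoxyphenyl replaces 3-chloro-4-fluorophenyl on the sulfonyl sulfur and gives a 3.3-fold higher number from compound 1 to compound 4 (0.52 log units; beyond the scatter) so the low number of compound 1 goes with that group and not with the 4-chlorophenyl that it shares with compound 4.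

Nothing available here explains why either place behaves as it does. As far as these compounds go, it also remains open whether a group of another kind at the 4-chlorophenyl position, such as an amine or a carboxylic acid, would stay within the scatter, and which of the two substituents on the 3-chloro-4-fluorophenyl ring goes with the low number.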